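Trifluoromethyl Analogue Weighed Against Two Measured Steps

The compounds below may be only part of what the source reports. "The series", "measured", "known", "first", "only" and "open" are said of these compounds alone.

Compound 1, `c1ccc(C2=NN(c3ccc(-c4ccccc4)nn3)C(c3ccccc3)C2)cc1`, in a functional assay on Caco-2 cells (Homo sapiens) for antiproliferative activity, read by MTT assay, with a stated time of 24 h (a higher number here means a weaker inhibitor, a lower number a stronger inhibitor), gives 40900 nM.
Compound 2, `COc1ccc(C2CC(c3ccccc3)=NN2c2ccc(-c3ccccc3)nn2)cc1`, in this assay reaches only a limit of the assay, > 100000 nM.
Compound 3, `Clc1ccc(C2=NN(c3ccc(-c4ccccc4)nn3)C(c3ccccc3)C2)cc1`, in this assay gives 100000 nM.

Of the two compounds that return a number, compound 3 has the higher one; the step of a 2.4-fold higher number from compound 1 to compound 3 (0.39 log units; beyond the scatter) separates it from compound 1, and the value of compound 2 is a limit rather than a number. Compound 4, `FC(F)(F)c1ccc(C2CC(c3ccc(Cl)cc3)=NN2c2ccc(-c3ccccc3)nn2)cc1`, differs from compound 3 by trifluoromethyl in place of hydrogen on an aromatic carbon. Among the measured compounds shown here, two measured steps bear on this kind of change, each adding a substituent to an aromatic carbon of the shared core: an at least 2.4-fold higher number from compound 1 to compound 2 (0.38 log units; beyond the scatter) and a 2.4-fold higher number from compound 1 to compound 3 (0.39 log units; beyond the scatter). Both run toward a higher number, and the methoxy step ends at the limit of > 100000 nM in this assay, at which 1 of the 3 values shown sits. Compound 4 carries a second such substituent on top of the chloro already present, so a step of similar size in the same direction in this assay is expected for compound 4, a 1.6-fold higher number from compound 3 to compound 4 (0.20 log units; within the scatter), with a fair chance that only the limit is reported. On that basis compound 4 is estimated in this assay at 160000 nM, within 60000 nM to 400000 nM.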

Compound 4, half-maximal inhibitory concentration: 10000 nM
Compound 4: the middle estimate sits 16-fold (1.20 log units) above what was measured; measured number below the stated range.
By their numbers in this assay, from the lowest: compound 4; then compound 1; then compound 3.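

Among the compounds shown here, the new step (a 10-fold lower number from compound 3 to compound 4 (1.00 log units; beyond the scatter)) is the first here to run toward a lower number, so adding a group to an aromatic carbon of the shared core does not by itself give a weaker inhibitor in this assay. The pattern of upward steps now holds only for compound 2 and compound 3, while compound 4 goes against it, and the presence of the chloro in compound 3 does not stop the number from falling once trifluoromethyl enters para to a large group. Nothing measured among these compounds explains why the direction reverses with this group at this place.

As far as these compounds go, it remains open whether the fall belongs to trifluoromethyl alone or would also follow from an amine, a carboxylic acid or a nitrile at the same place. From the compounds shown here alone, it is equally open whether trifluoromethyl would lower the number on the core of compound 1, without the chloro, or whether the step seen here holds only with the chloro present.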